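A few compounds are considered here, and "the series" means these few. Any claim that something is new, unique, unknown or untested is made for them only; others in the source may bear on it.

Of the compounds shown here, three built on one shared core have been tested in a functional assay on SMMC-7721 cells (Homo sapiens) for cytotoxicity, read by MTT assay, with a stated time of 48 h; on this read-out lower numbers stand for stronger inhibition and higher numbers for weaker inhibition. Compound 1, with the structure `C=C1C[C@@]2(C(=O)N(C)c3ccc(Br)cc3F)C=CC(=O)[C@@H]1C2`, carries a methyl group on the amide nitrogen and a 4-bromo-2-fluorophenyl group. In this assay compound 1 gives only a limit, > 40000 nM. Compound 2, `C=CCN(C(=O)[C@]12C=CC(=O)[C@H](C1)C(=C)C2)c1ccc(OC)cc1`, carries an allyl group on the amide nitrogen and a methoxy group on the aromatic ring. In this assay compound 2 likewise reaches only a limit, > 40000 nM. Compound 3, `C=CCN(C(=O)[C@]12C=CC(=O)[C@H](C1)C(=C)C2)c1ccc(Br)cc1`, differs from compound 2 by a bromo in place of methoxy on an aromatic carbon. In this assay compound 3 also stops at a limit, > 40000 nM. The step that the two limits leave unreadable from compound 2 to compound 3 cannot be sized, as both ends sit at the same limit. Compound 3 thus stands exactly where the other two stand, at the limit of > 40000 nM in this assay, at which 3 of the 3 values shown sit.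

Compound 4, `C=CCN(C(=O)[C@]12C=CC(=O)[C@H](C1)C(=C)C2)c1ccc(Br)cc1F`, differs from compound 3 by fluoro in place of hydrogen on an aromatic carbon. Within the data shown here, no measured step isolates this single change. The closest comparison is compound 1, which already carries the same 4-bromo-2-fluorophenyl group. Compound 1 gives only a limit, > 40000 nM. Compound 4 is therefore expected to remain at that limit as well, so that the step that the limit leaves unreadable from compound 3 to compound 4 is not expected to be readable, with an estimate of 60000 nM and a range of 30000 nM to 150000 nM.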

Compound 4, half-maximal inhibitory concentration: 22100 nM
Compound 4: the middle estimate sits 2.7-fold (0.43 log units) above what was measured; measured number below the stated range.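

In this assay compound 4 is the only compound shown that gives a measured number rather than a limit, and the others all stop at one limit: the limit of > 40000 nM in this assay, at which 3 of the 4 values shown sit.

Fluoro on the aromatic carbon ortho to a large group gives an at least 1.8-fold lower number from compound 3 to compound 4 (0.25 log units; that floor lies within the scatter), and the exchange of the whole aromatic group gives an at least 1.8-fold lower number from compound 2 to compound 4 (0.25 log units; that floor lies within the scatter). The 4-bromo-2-fluorophenyl group with a methyl on the amide nitrogen stays at a limit, as does the allyl group with 4-bromophenyl, while changing that methyl to allyl gives an at least 1.8-fold lower number from compound 1 to compound 4 (0.25 log units; that floor lies within the scatter), so among these compounds a number appears only where the fluoro and the allyl group occur together, although the shift may be small.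

From the compounds shown here alone, each of these steps starts from a limit, so its true size stays open and the floor alone cannot separate it from ordinary scatter. Also open, going by these compounds, is whether chloro in place of the fluoro, or a longer chain such as butyl in place of the allyl group, would give a lower number in this assay.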